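Bromo in Place of Iodo: a Halogen Swap

The compounds below may be only part of what the source reports. "The series", "measured", "known", "first", "only" and "open" are said of these compounds alone.

Compound 1 `O=C1C(Nc2ccccc2)=CC(=O)c2ncncc21` carries an unsubstituted aniline-like group on the shared core. In a functional assay on SK-MEL-2 cells (Homo sapiens) for cytotoxicity, read by MTT assay, with a stated time of 72 h (on this read-out higher numbers stand for weaker inhibition and lower numbers for stronger inhibition), compound 1 gives 0.01 ug/mL. Compound 2 `O=C1C(Nc2ccc(I)cc2)=CC(=O)c2ncncc21` adds an iodo group, and in this assay compound 2 gives 0.02 ug/mL. The change a 2.0-fold higher number from compound 1 to compound 2 (0.30 log units; within the scatter) stays within the scatter, so the two numbers cannot be told apart with confidence; compound 2 is simply the higher of the two numbers seen so far.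

Compound 3 `O=C1C(Nc2ccc(Br)cc2)=CC(=O)c2ncncc21` is the next candidate. The change is bromo in place of iodo on an aromatic carbon. Among the compounds with values here, the only measured step that bears on this position is from compound 1 to compound 2, where introducing a halogen left the number within the scatter. Exchanging one halogen for a closely related one is therefore expected to produce no step beyond the scatter, no change at the digits printed from compound 2 to compound 3 (within the scatter). Compound 3 is estimated at 0.02 ug/mL, with a likely range from 0.007 ug/mL to 0.06 ug/mL.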

Compound 3, half-maximal inhibitory concentration: 0.02 ug/mL
Compound 3: middle estimate and measured number agree at the digits printed; the range from low to high includes it.
By their numbers in this assay, from the lowest: compounds 1, 2 and 3 (each within the scatter of the next).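

In this assay, bromo in place of iodo on this aromatic carbon, para to a large group, gives no change at the digits printed from compound 2 to compound 3 (within the scatter), while bromo in place of hydrogen gives a 2.0-fold higher number from compound 1 to compound 3 (0.30 log units; within the scatter). Compound 2 alone could not show whether iodo was a special case, but compound 3 shows that a second halogen at this place also stays within the scatter of the unsubstituted compound 1, so the three compounds cannot be told apart here. Nothing available explains why these numbers stay so close.

The compounds shown cover only hydrogen, iodo and bromo at this one place. As far as these compounds go, it remains open whether a group of another kind, such as an amine, a carboxylic acid or a longer chain, would also stay within the scatter.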